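The source may hold more compounds than are shown below. What is called first, only, known or untested is meant among the compounds shown, and "the series" means these compounds.

Of the compounds shown here, three sharing one core have been measured so far in a physicochemical assay for solubility, at pH 7.4 (a higher number here means a more soluble compound, a lower number a less soluble compound), and none of them forms a single-place pair with another. Compound 2 (`COC(=O)c1ccc(NC(=O)Nc2cc(C)nc3ccccc23)cc1`) stands highest of the three at 1200 nM and lies beyond the scatter from both others. Compound 1 (`Cc1cc(NC(=O)Nc2ccc(C)c(Cl)c2)c2ccccc2n1`) gives 300 nM on the same read-out, and compound 3 (`Cc1cc(NC(=O)Nc2ccccc2C(N)=O)c2ccccc2n1`) gives 200 nM on it too.

The next compound to be measured is compound 4 (`Cc1cc(NC(=O)Nc2ccc(N)cc2)c2ccccc2n1`), which departs from compound 2 in one place. It carries amino in place of methoxycarbonyl on an aromatic carbon of a six-membered aromatic ring of carbon only, para to a large group (amino in place of methoxycarbonyl on an aromatic carbon).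

Within the data shown here, no measured pair shows what this exchange does on its own, so the data offer no direct guide to its size or direction. The expectation therefore starts from compound 2 at 1200 nM and stays broad, and no step beyond the scatter is expected in this assay for this exchange. The expected change, a 1.3-fold higher number from compound 2 to compound 4 (0.10 log units; within the scatter), is an estimate that stays within the scatter. For compound 4 the estimated value is 1500 nM, with 400 nM to 6000 nM as the expected range.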

Compound 4, solubility: 18500 nM
Compound 4: middle estimate off by 12-fold (1.09 log units), on the low side; measured number outside the range, above it.
By their numbers in this assay, from the lowest: compounds 3 and 1 (each within the scatter of the next); then compound 2; then compound 4.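

In this assay, among these compounds, amino in place of methoxycarbonyl on an aromatic carbon of the six-membered aromatic ring of carbon only, para to a large group, gives a 15-fold higher number from compound 2 to compound 4 (1.19 log units; beyond the scatter), and this first single-place pair shows that one exchange at this position can move the number by a large step, which the earlier compounds, none of them paired, could not show. The pair changes several counted features at once: methoxycarbonyl, with 4 heavy atoms, 0 hydrogen-bond donors and 2 hydrogen-bond acceptors, gives way to amino, with 1 heavy atom, 1 hydrogen-bond donor and 1 hydrogen-bond acceptor, so this single step cannot assign the change to any one of them. No measurement at hand bears on why the number moves.

The compounds shown leave open whether a hydroxyl, a carboxylic acid or a dimethylamino group on the same aromatic carbon would give a number close to that of amino. They also leave open whether the exchange of methoxycarbonyl for amino would give a step of similar size at another place on this ring.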